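The source may hold more compounds than are shown below. What is called first, only, known or untested is meant among the compounds shown, and "the series" means these compounds.

Of the compounds shown here, three have so far been measured in a functional assay on HEK293 cells for antagonist activity at transient receptor potential cation channel subfamily V member 1 (Rattus norvegicus); on this read-out higher numbers stand for weaker inhibition and lower numbers for stronger inhibition. Compound 1 `O=C(Nc1ccc(Oc2ccccc2)cc1)N1CCN(c2ncccc2C(F)(F)F)CC1` gives 258 nM, compound 2 `CC(C)c1ccc(NC(=O)N2CCN(c3ncccc3C(F)F)CC2)cc1` gives 27.7 nM, and compound 3 `O=C(Nc1ccc(C(F)(F)F)cc1)N1CCN(c2ncccc2Cl)CC1` gives 63.5 nM. Compound 3 thus stands second highest of the three numbers: its nearest neighbour is compound 2, whose number is lower by more than the scatter, while compound 1 lies furthest away, with a number higher by more than the scatter.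

Compound 4 `O=C(Nc1ccc(Br)cc1)N1CCN(c2ncccc2Cl)CC1` differs from compound 3 in one place: bromo in place of trifluoromethyl on an aromatic carbon, on an aromatic carbon of a six-membered aromatic ring of carbon only. Within the data shown here, no measured pair shows this exchange, so its effect is unknown. The step of a 1.3-fold higher number from compound 3 to compound 4 (0.13 log units; within the scatter) is expected to be small, a slight weakening if anything. Compound 4 is therefore estimated at 85 nM, with a range from 25 nM to 280 nM.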

Compound 4, half-maximal inhibitory concentration: 491 nM
Compound 4: the middle estimate sits 5.8-fold (0.76 log units) below what was measured; measured number outside the range, above it.
By their numbers in this assay, from the lowest: compound 2; then compound 3; then compounds 1 and 4 (each within the scatter of the next).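

Putting bromo in place of trifluoromethyl on this aromatic carbon gives a 7.7-fold higher number from compound 3 to compound 4 (0.89 log units; beyond the scatter) in this assay, which means clearly weaker inhibition. The earlier compounds shown here offered no pair that tested this position, and this single pair shows that the choice of group here can matter, at least on the core of compound 3. Nothing available bears on why the two groups differ.

From the compounds shown here alone, it remains open how fluoro, methyl or nitrile would fare at this position. Going by these compounds, whether the exchange has a similar effect on other cores also remains open.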